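A few compounds are considered here, and "the series" means these few. Any claim that something is new, unique, unknown or untested is made for them only; others in the source may bear on it.

In a functional assay on CHO cells for antagonist activity at Orexin receptor type 2 (Homo sapiens), read by FLIPR and calcium flux (a lower number here means a stronger inhibitor, a higher number a weaker inhibitor), three compounds sharing one core have been measured. Compound 1 `CCn1nc(C)c2c1CCN([C@@H](C(=O)NC)c1ccccc1)[C@H]2CCc1ccc(C(F)(F)F)cc1` gives 3 nM. Compound 2 `CCn1nc(C)c2c1CCN([C@@H](C(=O)NC)c1ccccc1)[C@H]2COc1ccc(C)cc1` gives 19 nM, and compound 3 `CCn1nc(C)c2c1CCN(C(C(=O)NC)c1ccccc1)C2CCc1cccc(C)c1` gives 19 nM. Compound 2 thus stands level with compound 3 at the digits shown, the two together at the high end of the three numbers, while compound 1 sits furthest from it with the lowest number of the set.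

Within the data shown here, the only single-point step among the measured compounds is a 6.3-fold higher number from compound 1 to compound 2 (0.80 log units; beyond the scatter), which replaces 4-(trifluoromethyl)benzyl with 4-methylphenoxy on a saturated chain carbon bound to a saturated ring carbon.

Compound 4 `CCn1nc(C)c2c1CCN([C@@H](C(=O)NC)c1ccccc1)[C@H]2CCc1ccc(C(C)C)cc1` has not yet been measured in this assay. It differs from compound 2 in that (4-isopropylbenzyl in place of 4-methylphenoxy on a saturated chain carbon bound to a saturated ring carbon). This change runs in the opposite sense to the measured step, returning a benzyl-type group to the same place, though with isopropyl rather than trifluoromethyl on the ring. On that basis compound 4 is expected to move back toward compound 1, with a step of about a 3.8-fold lower number from compound 2 to compound 4 (0.58 log units; beyond the scatter). The estimate for compound 4 in this assay is therefore 5 nM, within a range from 2 nM to 15 nM.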

Compound 4, half-maximal inhibitory concentration: 9 nM
For compound 4 the middle estimate is 1.8-fold (0.26 log units) below the measured one; the measured number falls inside the stated range.
By their numbers in this assay, from the lowest: compound 1; then compound 4; then compounds 2 and 3 (each within the scatter of the next).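

In this assay, 4-isopropylbenzyl in place of 4-methylphenoxy on a saturated chain carbon bound to a saturated ring carbon gives a 2.1-fold lower number from compound 2 to compound 4 (0.32 log units; beyond the scatter) and so shows that a lower number at this place is not confined to the 4-(trifluoromethyl)benzyl of compound 1. Among these compounds, the ring substituent matters as well: isopropyl in place of trifluoromethyl on an aromatic carbon gives a 3.0-fold higher number from compound 1 to compound 4 (0.48 log units; beyond the scatter) and is the first step that can be read at the aromatic ring alone, with the chain left unchanged. Together these steps show that compound 4, which carries no fluorine, still stands beyond the scatter from compound 2, while compound 1 retains the lower number of the pair formed with compound 4.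

The step from compound 2 to compound 4 changes the chain and the ring substituent at once, so the compounds shown cannot separate the two, and it remains open how a 4-methylbenzyl group, or a ring bearing an amine or a carboxylic acid, would read at this place. No supporting data accompany these results to explain the order of the groups.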